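The compounds below may be only part of what the source reports. "The series", "measured", "known", "first", "only" and "open" are said of these compounds alone.

Compound 1 `COC(=O)C1=C(C)N=C(C)/C(=C(\O)OC)C1c1cccc(N(C)C)c1` and compound 2 `COC(=O)C1=C(C)N=C(C)/C(=C(\O)OC)C1c1ccc(C#N)cc1` share one core. In a functional assay (muscle tissue) with Cavia porcellus as the target (a higher number here means that more compound is needed for the effect, a lower number that less compound is needed), compound 1 gives 891 nM, while in this assay compound 2 gives 3470 nM, the higher of the two numbers, its gap to compound 1 lying beyond the scatter. Compound 3 `COC(=O)C1=C(C)N=C(C)/C(=C(\O)OC)C1c1cccc(OC)c1` has not been measured; it differs from compound 2 by 3-methoxyphenyl in place of 4-cyanophenyl on a saturated ring carbon. Because compound 1 gives 891 nM, compound 3 is expected to need less compound than compound 2. That expected step is estimated at a 3.2-fold lower number from compound 2 to compound 3 (0.50 log units; beyond the scatter). In this assay compound 3 is estimated at 1100 nM, with a range from 300 nM to 4000 nM.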

Compound 3, half-maximal effective concentration: 191 nM
For compound 3 the middle estimate is 5.8-fold (0.76 log units) above the measured one, and the stated range ends above it.
By their numbers in this assay, from the lowest: compound 3; then compound 1; then compound 2.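

In this assay, going by these compounds alone, the group on the saturated ring carbon can shift the number widely: 3-methoxyphenyl in place of 4-cyanophenyl gives an 18-fold lower number from compound 2 to compound 3 (1.26 log units; beyond the scatter), the largest step so far. Methoxy in place of dimethylamino on an aromatic carbon still gives a 4.7-fold lower number from compound 1 to compound 3 (0.67 log units; beyond the scatter), so the identity of this single group matters as well. Nothing measured here accounts for either step.

The step from 4-cyanophenyl changes both the group and where it sits on the phenyl ring, and these remain unseparated. A 3-cyanophenyl or 4-methoxyphenyl group would separate them, while a longer ethoxy chain would test how far methoxy can be extended.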